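The source may hold more compounds than are shown below. What is called first, only, known or untested is meant among the compounds shown, and "the series" means these compounds.

Measured compounds:
- compound 1, `O=C(Nn1c(-c2cccc([N+](=O)[O-])c2)nc2c(-c3ccco3)n[nH]c2c1=O)c1cccnc1`: 11.7%
- compound 2, `COc1cccc(-c2nc3c(-c4ccco4)n[nH]c3c(=O)n2NC(=O)c2cccnc2)c1`: 12.8%
- compound 3, `O=C(Nn1c(-c2cccc([N+](=O)[O-])c2)nc2c(-c3cccs3)n[nH]c2c1=O)c1cccnc1`: 3.9%

In a functional assay on HT-29 cells (Homo sapiens) for cytotoxicity, read by sulforhodamine B assay, with a stated time of 2 days, tested at 100 uM (a higher number here means more inhibition at the concentration tested (going by the name of the read-out), a lower number less inhibition), compound 2 gives 12.8%, the largest of the three numbers, though its gaps to compound 1 and to compound 3 both lie within the scatter, so no order among the three can be read from them. The two single-point changes recorded so far are a number 1.1 percentage points higher from compound 1 to compound 2 (within the scatter) and a number 7.8 percentage points lower from compound 1 to compound 3 (within the scatter), neither of which leaves the scatter. Compound 2 and compound 3 differ in two places at once and their values sit close together.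

Compound 4, `COc1cccc(-c2nc3c(-c4ccco4)n[nH]c3c(=O)n2NC(=O)c2ccccc2)c1`, differs from compound 2 at the carbonyl carbon: phenyl in place of pyridin-3-yl on a carbonyl carbon. Within the data shown here, none of the measured steps touches this part of the molecule; the recorded changes concern the group on the aromatic carbon and the five-membered ring, and both proved flat. There is thus no direct evidence for the carbonyl substituent, only the observation that the series has so far moved within the scatter whatever was changed. A step of similar size, that is none beyond the scatter, is expected for a number 0.8 percentage points lower from compound 2 to compound 4 (within the scatter). Compound 4 is estimated at 12%, within 2% to 22%.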

Compound 4, a percentage reported as inhibition, at one concentration (the size of the read-out at that concentration, not a potency): 49.8%
Beside the measured number, compound 4's estimate is 37.8 percentage points below it; the measured number lies above the stated range.
By their numbers in this assay, from the lowest: compounds 3, 1 and 2 (each within the scatter of the next); then compound 4.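

Among these compounds, the carbonyl substituent is the first place where a change clearly moves the read-out in this assay: phenyl in place of pyridin-3-yl on a carbonyl carbon gives a number 37 percentage points higher from compound 2 to compound 4 (beyond the scatter) and so stands apart from the earlier changes, which stayed within the scatter. Both groups have 6 heavy atoms and a six-membered aromatic ring, and the difference lies in the ring nitrogen and its hydrogen-bond acceptor, so the series is sensitive to a swap that leaves the ring size unchanged. No measurement at hand accounts for the size of this step.

On these data alone, only compound 2 and compound 4 speak to this position, so it remains open whether benzamido has the same effect with nitro in place of methoxy, or with thiophen-2-yl in place of furan-2-yl. Also open, as far as these compounds go, is how the read-out responds when the carbonyl carbon carries a saturated amine such as piperidine, a phenyl bearing a carboxylic acid, or a longer alkyl chain.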